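Aryl exchange from compound 3 to compound 4

The source may hold more compounds than are shown below. What is called first, only, known or untested is meant among the compounds shown, and "the series" means these compounds.

Measured in a functional assay on CCRF-CEM cells (Homo sapiens) for antiproliferative activity (on this read-out lower numbers stand for stronger inhibition and higher numbers for weaker inhibition), on the shared core:
- compound 1 `COc1cc(C(=O)c2sc(-c3ccc(Br)cc3)cc2N)cc(OC)c1OC` gives 86 nM
- compound 2 `COc1cc(C(=O)c2sc(-c3cccc([N+](=O)[O-])c3)cc2N)cc(OC)c1OC` gives 5.9 nM
- compound 3 `COc1cc(C(=O)c2sc(-c3ccc(Cl)c(Cl)c3)cc2N)cc(OC)c1OC` gives 290 nM

Compound 3, at 290 nM, has the highest number of the three. Compound 4 `COc1cc(C(=O)c2sc(-c3ccc(C)cc3)cc2N)cc(OC)c1OC` is still unmeasured and has 4-methylphenyl in place of 3,4-dichlorophenyl on an aromatic carbon. The closest guide is the modest 3.4-fold higher number from compound 1 to compound 3 (0.53 log units; beyond the scatter), since 4-methylphenyl, like the 4-bromophenyl of compound 1 (86 nM), is a singly substituted phenyl. Among the measured compounds shown here, the large 49-fold higher number from compound 2 to compound 3 (1.69 log units; beyond the scatter) bears less directly, and no methyl analogue has been measured. In this assay the expected change is a 3.6-fold lower number from compound 3 to compound 4 (0.56 log units; beyond the scatter), a modest step to a lower number. Compound 4 is estimated at 80 nM, with an expected range from 20 nM to 300 nM in this read-out.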

Compound 4, half-maximal inhibitory concentration: 15 nM
Compound 4: middle estimate off by 5.3-fold (0.73 log units), on the high side, outside the stated range (below it).
By their numbers in this assay, from the lowest: compound 2; then compound 4; then compound 1; then compound 3.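

In this assay, the aromatic carbon next to the ring sulfur proves more sensitive to the identity of the phenyl substituents than compound 1 and compound 3 suggested: the exchange gives a 19-fold lower number from compound 3 to compound 4 (1.29 log units; beyond the scatter), and methyl in place of bromo gives a 5.7-fold lower number from compound 1 to compound 4 (0.76 log units; beyond the scatter). A singly substituted phenyl can therefore approach the 3-nitrophenyl result, although a gap remains, with a 2.5-fold higher number from compound 2 to compound 4 (0.41 log units; beyond the scatter). No available evidence accounts for these steps.

The compounds shown leave open whether 4-methoxyphenyl or 4-aminophenyl would match 4-methylphenyl, and whether 3-methylphenyl would give a lower number than compound 4.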